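Dropping a Methyl: What to Expect for Compound 4

The compounds below may be only part of what the source reports. "The series", "measured", "known", "first", "only" and "open" are said of these compounds alone.

Compound 1 `Cc1ccnc(/C(N)=N/NC(=S)N2CCSCC2)c1` and compound 2 `N/C(=N\NC(=S)N1CCSCC1)c1ccccn1` share one core. In a functional assay on HeLa cells (Homo sapiens) for cytotoxicity, read by MTT assay, with a stated time of 72 h, tested at 100 uM (a lower number here means less inhibition of growth, a higher number more inhibition of growth at the concentration tested), compound 1 gives 91.6%, and compound 2 gives 88.7%. The change between them, (hydrogen in place of methyl on an aromatic carbon), made a step of a number 2.9 percentage points lower from compound 1 to compound 2 (within the scatter). Compound 3 `Cc1cccc(/C(N)=N/NC(=S)N2CCCC2)n1` has another core; the difference between the two cores is not broken down here. In this assay compound 3 gives 80.1%. Compound 4 `N/C(=N\NC(=S)N1CCCC1)c1ccccn1` has not been measured and differs from compound 3 by hydrogen in place of methyl on an aromatic carbon. This is the same kind of change as seen before, though the place differs: here it is next to the ring nitrogen and meta to a large group, whereas before it was meta to a large group and opposite the ring nitrogen. Because a number 2.9 percentage points lower from compound 1 to compound 2 (within the scatter) was small, a small step is expected, a number 2.1 percentage points lower from compound 3 to compound 4 (within the scatter). Compound 4 is therefore estimated at 78%, expected between 65% and 90%.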

Compound 4, percent growth inhibition at one concentration: 89.1%
Compound 4: the middle estimate sits 11.1 percentage points below what was measured; the measured number falls inside the stated range.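

In this assay, hydrogen in place of methyl on an aromatic carbon gives a number 9 percentage points higher from compound 3 to compound 4 (within the scatter), and the two cases do not differ: the same change on two cores in this assay, a number 2.9 percentage points lower (within the scatter) from compound 1 to compound 2 and a number 9 percentage points higher (within the scatter) from compound 3 to compound 4, 11.9 percentage points apart, within the scatter of two such steps.

On these two cores, then, the change carries over as a step inside the usual scatter, and pyrrolidin-1-yl in place of thiomorpholin-4-yl on a thiocarbonyl carbon likewise gives a number 0.4 percentage points higher from compound 2 to compound 4 (within the scatter). This does not show that the change acts identically on every core, as each core offers a single pair and the methyl sits at a different place in each.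

The aromatic ring carries only methyl or hydrogen in the compounds shown. From the compounds shown here alone, how an amine, a carboxylic acid or a longer chain would behave there remains open.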